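Swapping the aryl group on the carbonyl of compound 2

This account rests on a few compounds, and the source may have more. Where it says the series, first, only, none or still open, it means among the compounds named here.

Compound 2 `COc1ccc(C(=O)/C=C/c2cc(-c3cc(OC)c(OC)c(OC)c3)n[nH]2)cc1OC` gives 2600 nM in a functional assay on SF-539 cells (Homo sapiens) for inhibition, read by sulforhodamine B assay, with a stated time of 48 h; on this read-out lower numbers stand for stronger inhibition of growth and higher numbers for weaker inhibition of growth; compound 1 `COc1cc(-c2cc(/C=C/C(=O)c3ccc(N)cc3)[nH]n2)cc(OC)c1OC` gives 2660 nM, and the step of a 1.0-fold lower number from compound 1 to compound 2 (0.01 log units; within the scatter) is within the scatter, so compound 2 sits with compound 1 on the numbers shown. Compound 3 `COc1cc(-c2cc(/C=C/C(=O)c3ccc(F)c(F)c3)[nH]n2)cc(OC)c1OC` differs from compound 2 by 3,4-difluorophenyl in place of 3,4-dimethoxyphenyl on a carbonyl carbon. Going by the values given here, the only step that bears on this change is a 1.0-fold lower number from compound 1 to compound 2 (0.01 log units; within the scatter), which shows that swapping the aryl group on the carbonyl left the read-out flat. Compound 3 is therefore expected to show a step of no change at the digits printed from compound 2 to compound 3 (within the scatter) in this assay, with an estimate of 2600 nM between 900 nM and 7500 nM.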

Compound 3, concentration for total growth inhibition: 17700 nM
Estimate against measurement, compound 3: 6.8-fold (0.83 log units) below, outside the stated range (above it).
By their numbers in this assay, from the lowest: compounds 2 and 1 (each within the scatter of the next); then compound 3.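

The aryl group on a carbonyl carbon is not interchangeable in this assay after all. With 3,4-difluorophenyl the read-out shows a 6.8-fold higher number from compound 2 to compound 3 (0.83 log units; beyond the scatter) and a 6.7-fold higher number from compound 1 to compound 3 (0.82 log units; beyond the scatter) so the flat step seen earlier held for 3,4-dimethoxyphenyl and 4-aminophenyl but not for every aryl group. Nothing available accounts for this weaker inhibition of growth. The compounds shown leave open whether 4-fluorophenyl or 3,4-dihydroxyphenyl on the carbonyl carbon would read with compound 3 or with compound 1 and compound 2.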